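Triazole series: benzyl replacing (ethoxycarbonyl)methyl on nitrogen

A few compounds are considered here, and "the series" means these few. Any claim that something is new, unique, unknown or untested is made for them only; others in the source may bear on it.

Compound 1 `CCOC(=O)Cn1cc(C(O)c2ccc3ccccc3c2)nn1` in a functional assay on B16 cells (Mus musculus) for cytotoxicity, read by MTT assay, with a stated time of 48 h (on this read-out lower numbers stand for stronger inhibition and higher numbers for weaker inhibition), reaches only the limit > 100000 nM.
Compound 2 `COc1cccc(Cn2cc(-c3ccc4ccccc4c3)nn2)c1` in this assay likewise gives the limit > 100000 nM.
Compound 3 `CC1(C)OCC(Cn2cc(-c3ccc4ccccc4c3)nn2)O1` in this assay gives 6600 nM.

Compound 1 thus stands at the limit of > 100000 nM in this assay, at which 2 of the 3 values shown sit, with no number of its own. Compound 4 `OC(c1ccc2ccccc2c1)c1cn(Cc2ccccc2)nn1` differs from compound 1 by phenyl in place of ethoxycarbonyl on a saturated chain carbon bound to an aromatic nitrogen. For the measured compounds named here, the only measured step at this place is an at least 15-fold lower number from compound 2 to compound 3 (1.18 log units; beyond the scatter), which moves away from an aryl group rather than towards one; compound 2, carrying an aryl on that carbon, sits at the limit. Going by the values given here, no measured step bears directly on the change to compound 4, so in this assay no shift beyond the scatter is expected, and most likely again only a limit. Compound 4 is therefore estimated at 100000 nM, range 20000 nM to 400000 nM, meaning an expected step of a number no higher from compound 1 to compound 4 (the limit leaves the size open).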

Compound 4, half-maximal inhibitory concentration: 28800 nM
For compound 4 the middle estimate is 3.5-fold (0.54 log units) above the measured one; the range from low to high includes it.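

With phenyl in place of ethoxycarbonyl on a saturated chain carbon bound to an aromatic nitrogen, this assay shows an at least 3.4-fold lower number from compound 1 to compound 4 (0.54 log units; beyond the scatter). This place can therefore carry an aryl group and still give a measured number, which compound 2 did not show. The true size of the step stays open because compound 1 has only a limit: the limit of > 100000 nM in this assay, at which 2 of the 4 values shown sit.

As far as these compounds go, whether an amine, a carboxylic acid or a longer chain at this place would give a lower number remains open. Also open, from the compounds shown here alone, is how 2,2-dimethyl-1,3-dioxolan-4-yl would behave on the core of compound 4.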